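Swapping 3-methylphenyl for 2-chlorophenyl in a weak series

The source may report more compounds than this note shows. Statements on the series, on what has been measured and on what is new or still open speak of the compounds shown alone.

- compound 1 `Cc1ccccc1NNC(=O)c1cccc(NS(=O)(=O)c2cnc(O)nc2O)c1`: > 20000 nM (a limit)
- compound 2 `Cc1cccc(NNC(=O)c2cccc(NS(=O)(=O)c3cnc(O)nc3O)c2)c1`: > 20000 nM (a limit)

In a functional assay on SGC-7901 cells (Homo sapiens) for antiproliferative activity, read by MTT assay, with a stated time of 24 h (a lower number here means a stronger inhibitor, a higher number a weaker inhibitor), compound 2 gives > 20000 nM, which is a limit and not a number. The record so far is the limit of > 20000 nM in this assay, at which 2 of the 2 values shown sit. Compound 3 `O=C(NNc1ccccc1Cl)c1cccc(NS(=O)(=O)c2cnc(O)nc2O)c1` carries one change: 2-chlorophenyl in place of 3-methylphenyl on an amine nitrogen. Among the measured compounds shown here, the only measured step is a step that the two limits leave unreadable from compound 1 to compound 2, so it offers no size to carry over. No move beyond the usual scatter is therefore expected in this assay, and most likely the result is again a limit. The expected change is a step that the limit leaves unreadable from compound 2 to compound 3. For compound 3 the estimate is 30000 nM, with an expected range from 12000 nM to 80000 nM.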

Compound 3, half-maximal inhibitory concentration: 2270 nM
Compound 3: the middle estimate sits 13-fold (1.12 log units) above what was measured; the whole stated range lies above it.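

In this assay, compound 3 gives a readable number, while the other two compounds stop at a limit: the limit of > 20000 nM in this assay, at which 2 of the 3 values shown sit. Placing 2-chlorophenyl on the amine nitrogen produces an at least 8.8-fold lower number from compound 2 to compound 3 (0.94 log units; beyond the scatter), and chloro in place of methyl on an aromatic carbon produces an at least 8.8-fold lower number from compound 1 to compound 3 (0.94 log units; beyond the scatter). So this position can respond to a change of group, and exchanging methyl for chloro on the ring is enough to show it.

The step from compound 1 to compound 2 cannot be read. On these data alone, whether 3-chlorophenyl, 2-fluorophenyl or 2-bromophenyl would keep this gain stays open.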